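The source may hold more compounds than are shown below. What is called first, only, known or untested is meant among the compounds shown, and "the series" means these compounds.

Working notes on the series. In an assay on isolated protein for inhibition of RAC-alpha serine/threonine-protein kinase (Homo sapiens), read by mobility shift assay, tested at 30 uM (a higher number here means more inhibition at the concentration tested (going by the name of the read-out), a lower number less inhibition), compound 1 `Nc1n[nH]c2cc(-c3cccnc3)[nH]c(=O)c12` gives 7%. Compound 2 `Cc1cc2nn(-c3ccccc3)c(N)c2c(=O)[nH]1`, with a methyl on the core, gives 5% in this assay, a number within the usual scatter of that of compound 1, so the two cannot be ordered. Compound 3 `CC(C)(C)c1cc2nn(-c3ccccc3)c(N)c2c(=O)[nH]1` carries the change (tert-butyl in place of methyl on an aromatic carbon). Within the data shown here, no step between measured compounds is available to size this change; with both measured numbers low and alike, compound 3 is expected to move by a number 1 percentage points higher from compound 2 to compound 3 (within the scatter), no step beyond the scatter. Compound 3 is estimated at 6%, range -5% to 18%.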

Compound 3, a percentage reported as inhibition, at one concentration (the size of the read-out at that concentration, not a potency): 7%
Beside the measured number, compound 3's estimate is 1 percentage points below it, within the range that was stated.
By their numbers in this assay, from the lowest: compounds 2, 1 and 3 (each within the scatter of the next).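

In this assay, tert-butyl in place of methyl on an aromatic carbon, next to the ring nitrogen, gives a number 2 percentage points higher from compound 2 to compound 3 (within the scatter). Among these compounds, this is the first sized step at this position, and going from one heavy atom to four leaves the number low, with no step beyond the scatter. No measurement on hand explains this result.

Still open, on these data alone, is whether an amine or a carboxylic acid at this position would move the number beyond the scatter. Also open, as far as these compounds go, is whether the phenyl on the shared core could be exchanged with a larger effect.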